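The source may hold more compounds than are shown below. What is called first, only, known or untested is meant among the compounds shown, and "the series" means these compounds.

Among the measured compounds shown here, in an assay on isolated protein for inhibition of coagulation factor X (Oryctolagus cuniculus), tested at 1 uM (a lower number here means less inhibition, a higher number more inhibition at the concentration tested (going by the name of the read-out)), compound 2 `O=C1[C@@H](NS(=O)(=O)c2ccc(-c3ccon3)s2)CCN1CCNc1ccncc1` gives 22%, the higher of the two numbers known, while compound 1 `O=C1[C@@H](NS(=O)(=O)c2ccc(-c3ccccn3)s2)CCN1Cc1cc2c[nH]ccc-2n1` gives 11%, a gap that lies beyond the usual scatter. Compound 3 `O=C1[C@@H](NS(=O)(=O)c2ccc(-c3ccccn3)s2)CCN1CCNc1ccncc1` is compound 2 with a single change: pyridin-2-yl in place of 1,2-oxazol-3-yl on an aromatic carbon. Compound 1 already carries the pyridin-2-yl group and reads lower than compound 2, so this account expects compound 3 to sit somewhat below compound 2, a step of a number 6 percentage points lower from compound 2 to compound 3 (within the scatter) that may well fall within the scatter. The estimated value for compound 3 in this assay is 16%, within a range from 4% to 34%.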

Compound 3, a percentage reported as inhibition, at one concentration (the size of the read-out at that concentration, not a potency): 18%
The estimate for compound 3 lay 2 percentage points below the measured number; the range from low to high includes it.
By their numbers in this assay, from the lowest: compounds 1, 3 and 2 (each within the scatter of the next, the first and the last beyond it).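

In this assay the change on the aromatic carbon next to the ring sulfur gives a number 4 percentage points lower from compound 2 to compound 3 (within the scatter), so pyridin-2-yl and 1,2-oxazol-3-yl cannot be told apart at this place. The change on the saturated chain carbon bound to an amide-type nitrogen in a ring gives a number 7 percentage points higher from compound 1 to compound 3 (within the scatter), so those two groups cannot be told apart either. Nothing at hand explains these readings. On these data alone, a phenyl group, an amine or a carboxylic acid on that aromatic carbon remains open, as does whether any of them would shift the number beyond the scatter.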